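This account rests on a few compounds, and the source may have more. Where it says the series, first, only, none or still open, it means among the compounds named here.

Measured so far in a functional assay on HCT-116 cells (Homo sapiens) for antiproliferative activity, read by MTT assay, with a stated time of 24 h; a lower number here means a stronger inhibitor, a higher number a weaker inhibitor:
Compound 1, `C#CCOc1ccc2c(=O)c(-c3cc(OC)c(OC)cc3OC)coc2c1`, gives 8050 nM.
Compound 2, `COc1cccc(C(=O)Oc2ccc3c(=O)c(-c4cc(OC)c(OC)cc4OC)coc3c2)c1`, sits at the limit of this assay, > 10000 nM.
Compound 3, `COc1cc(OC)c(-c2coc3cc(OCc4cccc(Cl)c4)ccc3c2=O)cc1OC`, gives 1330 nM.

Compound 2 thus stands at the limit of this assay, as the limit of > 10000 nM in this assay, at which 1 of the 3 values shown sits, records; no number is known for it. Compound 4, `COc1cc(OC)c(-c2coc3cc(OCc4ccccc4Cl)ccc3c2=O)cc1OC`, differs from compound 2 by 2-chlorobenzyl in place of (3-methoxyphenyl)carbonyl on an oxygen on an aromatic ring. The step that bears on this most directly is an at least 7.5-fold lower number from compound 2 to compound 3 (0.87 log units; beyond the scatter), and the same benzyl-type group also gave a 6.1-fold lower number from compound 1 to compound 3 (0.78 log units; beyond the scatter). Because an at least 7.5-fold lower number from compound 2 to compound 3 (0.87 log units; beyond the scatter) came with 3-chlorobenzyl entering at the same oxygen, and 2-chlorobenzyl likewise carries a chlorine on its ring, a step of similar size and direction is expected for compound 4, an at least 5.0-fold lower number from compound 2 to compound 4 (0.69 log units; beyond the scatter). Compound 4 is therefore expected to give about 2000 nM, between 700 nM and 6000 nM.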

Compound 4, half-maximal inhibitory concentration: 2450 nM
The estimate for compound 4 lay 1.2-fold (0.09 log units) below the measured number; the measured number falls inside the stated range.
By their numbers in this assay, from the lowest: compounds 3 and 4 (each within the scatter of the next); then compound 1. At a limit, above all of these: compound 2.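

In this assay, swapping 3-chlorobenzyl for 2-chlorobenzyl on this oxygen gives no change that can be told from scatter (a 1.8-fold higher number from compound 3 to compound 4 (0.27 log units; within the scatter)), so both chlorobenzyl groups serve about equally here. The 2-chlorobenzyl group also compares well with propargyl (a 3.3-fold lower number from compound 1 to compound 4 (0.52 log units; beyond the scatter)) and with (3-methoxyphenyl)carbonyl (an at least 4.0-fold lower number from compound 2 to compound 4 (0.61 log units; beyond the scatter)). That last step has only a floor, since compound 2 is known only as a limit: the limit of > 10000 nM in this assay, at which 1 of the 4 values shown sits.

Whether the chlorine matters at all remains open, as plain benzyl is not among the compounds shown. So does the effect of an amine on that ring, or of a longer chain between the oxygen and the ring.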